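Benzamide variation on the shared core

This account rests on a few compounds, and the source may have more. Where it says the series, first, only, none or still open, it means among the compounds named here.

Compound 1 `COc1ccc(C(=O)Nc2cccc(-c3ccnc4c(N)cccc34)c2)cc1OC` gives 9500 nM in a functional assay on A375P cells (Homo sapiens) for antiproliferative activity, read by MTT assay, with a stated time of 48 h; on this read-out lower numbers stand for stronger inhibition and higher numbers for weaker inhibition. Among the three measured numbers compound 1 stands second highest: compound 3 `Nc1cccc2c(-c3cccc(NC(=O)c4ccc(F)c(C(F)(F)F)c4)c3)ccnc12` gives 10400 nM, within the scatter of compound 1, while compound 2 `Nc1cccc2c(-c3cccc(NC(=O)c4ccc(Cl)c(C(F)(F)F)c4)c3)ccnc12` gives 1400 nM, the lowest. Going by the values given here, the only single-point step measured is a 7.4-fold higher number from compound 2 to compound 3 (0.87 log units; beyond the scatter), a halogen exchange on the benzamide ring. The change from compound 1 to compound 4 `Nc1cccc2c(-c3cccc(NC(=O)c4ccc5c(c4)OCCO5)c3)ccnc12` is different in kind: 2,3-dihydro-1,4-benzodioxin-6-yl in place of 3,4-dimethoxyphenyl on a carbonyl carbon. Among the compounds with values here, no measured step tests this change, so no step beyond the scatter is expected in this assay. Compound 4 is therefore estimated at 9000 nM (range 3000 nM to 27000 nM), an expected step of a 1.1-fold lower number from compound 1 to compound 4 (0.02 log units; within the scatter).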

Compound 4, half-maximal inhibitory concentration: 860 nM
Compound 4: middle estimate off by 10-fold (1.02 log units), on the high side, and the stated range ends above it.
By their numbers in this assay, from the lowest: compounds 4 and 2 (each within the scatter of the next); then compounds 1 and 3 (each within the scatter of the next).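

In this assay, 2,3-dihydro-1,4-benzodioxin-6-yl in place of 3,4-dimethoxyphenyl on a carbonyl carbon gives an 11-fold lower number from compound 1 to compound 4 (1.04 log units; beyond the scatter), so this position responds to more than the halogen exchange seen earlier. The two groups match in heavy atoms, hydrogen-bond acceptors and net charge, so those counts alone do not set the value here. No measurement available here accounts for the step.

Going by these compounds, whether the gain persists with 1,3-benzodioxol-5-yl, with its five-membered ring, remains open. So does the response of this carbonyl carbon to a morpholine or a longer chain.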